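Fluorophenyl for pyridyl in two sulfamate series

This account rests on a few compounds, and the source may have more. Where it says the series, first, only, none or still open, it means among the compounds named here.

This study examines three aryl sulfamates in an assay on HEK293 cells for inhibition of Steryl-sulfatase (Homo sapiens), tested at 0.1 uM; on this read-out higher numbers stand for a stronger effect at the one concentration tested and lower numbers for a weaker effect. Compound 1, with the structure `CCN(Cc1ccncc1)c1ccc(C(=O)N2CCc3ccc(OS(N)(=O)=O)cc3C2)cc1`, gives 47%. Compound 3, with the structure `CCN(Cc1ccc(F)cc1)c1ccc(C(=O)N2CCc3ccc(OS(N)(=O)=O)cc3C2)cc1`, gives 69.1%. The change between them is 4-fluorophenyl in place of pyridin-4-yl on a saturated chain carbon bound to a nitrogen on an aromatic ring, and the step it makes is a number 22.1 percentage points higher from compound 1 to compound 3 (beyond the scatter). Compound 2, with the structure `CCN(Cc1ccncc1)c1cccc(C(=O)N2CCc3ccc(OS(N)(=O)=O)cc3C2)c1`, gives 33.3%, the lowest of the three numbers. Compound 2 and compound 1 are built from the same atoms joined differently; the difference between the two cores is not broken down here.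

Compound 4, with the structure `CCN(Cc1ccc(F)cc1)c1cccc(C(=O)N2CCc3ccc(OS(N)(=O)=O)cc3C2)c1`, has not yet been measured. It differs from compound 2 by 4-fluorophenyl in place of pyridin-4-yl on a saturated chain carbon bound to a nitrogen on an aromatic ring, the same change that leads from compound 1 to compound 3, at the same place. Because the earlier step was a number 22.1 percentage points higher from compound 1 to compound 3 (beyond the scatter), a step of similar size is expected from compound 2 to compound 4, namely a number 19.7 percentage points higher from compound 2 to compound 4 (beyond the scatter). This expectation rests on one matched pair only, so the range is kept wide. Compound 4 is therefore estimated to give 53%, between 36% and 68%.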

Compound 4, a percentage reported as inhibition, at one concentration (the size of the read-out at that concentration, not a potency): 10.9%
Beside the measured number, compound 4's estimate is 42.1 percentage points above it, and the stated range ends above it.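

In this assay, putting 4-fluorophenyl in place of pyridin-4-yl on the core of compound 2 gave a number 22.4 percentage points lower from compound 2 to compound 4 (beyond the scatter), so the gain seen on the core of compound 1 did not carry over. Set side by side, the two steps point in opposite directions and are nearly equal in size: the same change on two cores in this assay, a number 22.1 percentage points higher (beyond the scatter) from compound 1 to compound 3 and a number 22.4 percentage points lower (beyond the scatter) from compound 2 to compound 4, 44.5 percentage points apart, beyond the scatter of two such steps This shows that, in these two matched pairs, the outcome of the change depends on the core it is made on, so a step measured on one core is no guide to the other; it does not show what underlies this dependence, or whether it extends to any other group or core.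

The compounds shown leave open whether a plain phenyl or a cyclohexyl at the same place would follow the pattern of either core. They also leave open whether the reversal would persist with a propyl in place of the ethyl on the nitrogen.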